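Anilino to cyclopropylamino: the step from compound 2 to compound 3

This account rests on a few compounds, and the source may have more. Where it says the series, first, only, none or still open, it means among the compounds named here.

For the measured compounds named here, in a functional assay on MDA-MB-231 cells (Homo sapiens) for inhibition, with a stated time of 72 h (a lower number here means a stronger inhibitor, a higher number a weaker inhibitor), compound 2 `Cc1cc(Cl)ccc1NC(=O)Nc1nc(Nc2ccccc2)cc(Sc2c[nH]c3ccccc23)n1` gives 17100 nM, the lowest of the two numbers measured so far. Compound 1 `O=C(Nc1ccccc1)Nc1nc(Nc2ccccc2)cc(Sc2c[nH]c3ccccc23)n1` gives 35900 nM in this assay. Going by the values given here, the only measured step, a 2.1-fold lower number from compound 1 to compound 2 (0.32 log units; beyond the scatter), concerns the other side of the shared core and does not bear on the position changed next. Compound 3 `Cc1cc(Cl)ccc1NC(=O)Nc1nc(NC2CC2)cc(Sc2c[nH]c3ccccc23)n1` differs from compound 2 in cyclopropyl in place of phenyl on a nitrogen on an aromatic ring. Among the compounds with values here, with no measured step at this position, no direction can be drawn from the series, and the change is treated as neutral with wide uncertainty. For compound 3 the expected step is a 1.0-fold lower number from compound 2 to compound 3 (0.00 log units; within the scatter), within the scatter. The estimate for compound 3 is 17000 nM, with a range from 6000 nM to 50000 nM.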

Compound 3, half-maximal inhibitory concentration: 14600 nM
The estimate for compound 3 lay 1.2-fold (0.07 log units) above the measured number; the range from low to high includes it.
By their numbers in this assay, from the lowest: compounds 3 and 2 (each within the scatter of the next); then compound 1.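

For the compounds shown here, at this nitrogen on an aromatic ring, the first reading in this assay is a 1.2-fold lower number from compound 2 to compound 3 (0.07 log units; within the scatter). Cyclopropyl, with its three-membered non-aromatic ring and 3 heavy atoms, therefore reads the same as phenyl, with its six-membered aromatic ring and 6 heavy atoms, so in this pair an aromatic ring at this place is not needed to hold the number. No measured evidence on these compounds speaks to this result. Open, as far as these compounds go, is how a longer alkyl chain, a morpholine or a carboxylic acid on this nitrogen would read. Also open, from the compounds shown here alone, is whether cyclopropyl reads the same when the amide-type nitrogen carries the phenyl of compound 1.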